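A shorter hydroxamate arm on the shared core

A few compounds are considered here, and "the series" means these few. Any claim that something is new, unique, unknown or untested is made for them only; others in the source may bear on it.

Compound 1 `O=C(NO)c1cccc(-c2cn([C@@H]3C[C@H](C(=O)O)N(CCCc4ccccc4)C3)nn2)c1` has been tested in an assay on Sf9 cells for inhibition of histone deacetylase 11 (Homo sapiens), read by fluorescence, tested at 0.5 uM; on this read-out higher numbers stand for more inhibition at the one concentration tested (going by the name of the read-out) and lower numbers for less inhibition; here compound 1 gives < 10%, which is a limit of the assay rather than a number. Two neighbours share this fate. Compound 2 `O=C(NO)c1cccc(-c2cn([C@@H]3C[C@H](CO)N(CCCc4ccccc4)C3)nn2)c1` gives < 10%, again a limit. Compound 3 `O=C(NO)c1cccc(-c2cn([C@@H]3C[C@H](C(=O)O)N(Cc4ccccc4)C3)nn2)c1` gives < 10%, also a limit. Hence a step that the two limits leave unreadable from compound 1 to compound 2 and a step that the two limits leave unreadable from compound 1 to compound 3 are both unreadable, and the limit of < 10% in this assay, at which 3 of the 3 values shown sit, is all that is known so far. Compound 4 `O=C(/C=C/c1cn([C@@H]2C[C@H](C(=O)O)N(CCCc3ccccc3)C2)nn1)NO` differs from compound 1 by 2-(hydroxycarbamoyl)ethenyl in place of 3-(hydroxycarbamoyl)phenyl on an aromatic carbon. Neither measured step touches this part of the molecule, so no size or direction can be drawn from them. Compound 4 is therefore expected to remain near the limit, an estimate of 15% spanning 0% to 45%. The step this estimate means, a number at least 5 percentage points higher from compound 1 to compound 4 (that floor lies within the scatter), is expected to be small.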

Compound 4, a percentage reported as inhibition, at one concentration (the size of the read-out at that concentration, not a potency): 11%
The estimate for compound 4 lay 4 percentage points above the measured number; the measured number falls inside the stated range.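

Among the compounds shown here, compound 4 gives the first real number in this assay, 11%, so this position on the five-membered aromatic ring can carry a change that is readable, unlike the changes elsewhere on the molecule. Replacing 3-(hydroxycarbamoyl)phenyl with 2-(hydroxycarbamoyl)ethenyl, which removes the six-membered aromatic ring, gives a number at least 1 percentage points higher from compound 1 to compound 4 (that floor lies within the scatter), so no real gain can be claimed. The picture stays close to the floor of the assay: the limit of < 10% in this assay, at which 3 of the 4 values shown sit.

The steps between the limits still cannot be read. On these data alone, it remains open whether a saturated ethyl chain in place of the ethenyl link, or an amine on the phenyl ring, would move the number beyond the scatter.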